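Triazole aryl swaps on a spirooxindole core

The compounds below may be only part of what the source reports. "The series", "measured", "known", "first", "only" and "open" are said of these compounds alone.

In a functional assay on HCT-116 cells (Homo sapiens) for antiproliferative activity, read by MTT assay, with a stated time of 48 h (a lower number here means a stronger inhibitor, a higher number a weaker inhibitor), compound 1, `N#CC1=C(N)Oc2c(N)cc3nc4ccccc4nc3c2C12C(=O)N(Cc1cnnn1-c1ccccc1Br)c1ccccc12`, gives 12400 nM. Compound 2, `COc1ccc(-n2nncc2CN2C(=O)C3(C(C#N)=C(N)Oc4c(N)cc5nc6ccccc6nc5c43)c3ccccc32)cc1`, reaches only a limit, > 50000 nM, so no number is known for it.

Among the measured compounds shown here, the step of an at least 4.0-fold higher number from compound 1 to compound 2 (0.60 log units; beyond the scatter) is the only measured change, a move from 2-bromophenyl to 4-methoxyphenyl on an aromatic nitrogen, and it cost activity. Compound 2 thus sits at the limit of > 50000 nM in this assay, at which 1 of the 2 values shown sits, with only a limit to show. Compound 3, `Cc1cc(C)cc(-n2nncc2CN2C(=O)C3(C(C#N)=C(N)Oc4c(N)cc5nc6ccccc6nc5c43)c3ccccc32)c1`, differs from compound 2 by 3,5-dimethylphenyl in place of 4-methoxyphenyl on an aromatic nitrogen. For the measured compounds named here, no measured step covers this particular exchange, so the expectation rests on where compound 2 stands rather than on a known trend. Compound 2 already lies at the limit. Compound 3 is therefore expected to stay near that limit, with a step estimated as an at least 1.1-fold lower number from compound 2 to compound 3 (0.04 log units; that floor lies within the scatter). In this assay compound 3 is expected to give about 45000 nM, within an estimated range of 15000 nM to 100000 nM.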

Compound 3, half-maximal inhibitory concentration: > 50000 nM
Compound 3 ended at the assay's limit; the forecaster's own chance of this, stated with the estimate: 60%; middle value at least 1.1-fold (0.04 log units) away from the limit.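

Compound 3 shows that the loss seen with 4-methoxyphenyl is not particular to that group: with 3,5-dimethylphenyl on the same aromatic nitrogen, this assay gives an at least 4.0-fold higher number from compound 1 to compound 3 (0.60 log units; beyond the scatter). Among the three compounds shown, only the 2-bromophenyl of compound 1 gives a readable value, and the two replacements, one with an oxygen and one of carbon only, both end in limits, so the step between compound 2 and compound 3 cannot be read. The series now presses against the ceiling of the assay: the limit of > 50000 nM in this assay, at which 2 of the 3 values shown sit.

The compounds shown leave open whether the activity of compound 1 depends on the bromine itself or on where it stands on the phenyl ring. They also leave open how an unsubstituted phenyl, a 2-chlorophenyl or a 2-aminophenyl would read here.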